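From 1-carboxyethyl to 1-carboxy-1-methylethyl on compound 2

The source may report more compounds than this note shows. Statements on the series, on what has been measured and on what is new or still open speak of the compounds shown alone.

Measured in a functional assay on DU-145 cells (Homo sapiens) for cytotoxicity, read by trypan blue exclusion, with a stated time of 96 h; on this read-out lower numbers stand for stronger inhibition and higher numbers for weaker inhibition:
compound 1 `COC(=O)C(Nc1cc(CS(=O)(=O)/C=C/c2c(OC)cc(OC)cc2OC)ccc1OC)c1ccc(F)cc1` gives 300 nM
compound 2 `COc1cc(OC)c(/C=C/S(=O)(=O)Cc2ccc(OC)c(N[C@@H](C)C(=O)O)c2)c(OC)c1` gives 25 nM

Compound 2 (25 nM) holds the lower of the two numbers. Compound 3 `COc1cc(OC)c(/C=C/S(=O)(=O)Cc2ccc(OC)c(NC(C)(C)C(=O)O)c2)c(OC)c1` differs from compound 2 in one place, (1-carboxy-1-methylethyl in place of 1-carboxyethyl on a nitrogen on an aromatic ring), with 1-carboxy-1-methylethyl in place of 1-carboxyethyl on a nitrogen on an aromatic ring. Within the data shown here, only one measured step bears on this, a 12-fold lower number from compound 1 to compound 2 (1.08 log units; beyond the scatter), a large one at that same nitrogen, but it replaced (4-fluorophenyl)(methoxycarbonyl)methyl, a very different group. It therefore sets no size for this smaller change. A modest move towards a higher number is expected in this assay, namely a 2.0-fold higher number from compound 2 to compound 3 (0.30 log units; within the scatter) as the estimated step. For compound 3 the estimate is 50 nM, with an expected range of 12 nM to 220 nM.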

Compound 3, half-maximal inhibitory concentration: 150 nM
For compound 3 the middle estimate is 3.0-fold (0.48 log units) below the measured one; the measured number falls inside the stated range.
By their numbers in this assay, from the lowest: compound 2; then compounds 3 and 1 (each within the scatter of the next).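

In this assay, a 6.0-fold higher number from compound 2 to compound 3 (0.78 log units; beyond the scatter) shows that even this small change on the nitrogen is read clearly, and that 1-carboxyethyl cannot be swapped freely for 1-carboxy-1-methylethyl. With a 2.0-fold lower number from compound 1 to compound 3 (0.30 log units; within the scatter), the scatter does not separate 1-carboxy-1-methylethyl from the very different (4-fluorophenyl)(methoxycarbonyl)methyl, so the carboxylic acid alone does not secure the low number of compound 2. Nothing available here explains the difference between compound 2 and compound 3. Still open, from the compounds shown here alone, is how the opposite stereocentre, a methyl ester, a primary amide or a longer chain such as 1-carboxypropyl would compare.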